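Notes on a shared core with varied leaving groups

The compounds below may be only part of what the source reports. "The series", "measured", "known", "first", "only" and "open" are said of these compounds alone.

Compound 1, `CC(C)[C@H](NC(=O)COc1cccc2ccccc12)C(=O)N[C@@H](CC(=O)O)C(=O)CSc1nc(-c2ccccc2)cs1`, in a functional assay on Jurkat cells (Homo sapiens) for inhibition (on this read-out lower numbers stand for stronger inhibition and higher numbers for weaker inhibition), gives > 200000 nM, which is a limit of the assay and not a number.
Compound 2, `CC(C)[C@H](NC(=O)COc1cccc2ccccc12)C(=O)N[C@@H](CC(=O)O)C(=O)COc1nc2ccccc2[nH]1`, in this assay gives > 200000 nM, likewise a limit and not a number.

Compound 2 thus stands at the limit of this assay; both values shown sit there, as the limit of > 200000 nM in this assay, at which 2 of the 2 values shown sit, records. Within the data shown here, the single step between measured compounds, a step that the two limits leave unreadable from compound 1 to compound 2, cannot be read, since both of its ends are limits.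

Compound 3, `CC(C)[C@H](NC(=O)COc1cccc2ccccc12)C(=O)N[C@@H](CC(=O)O)C(=O)COc1ccnc(C(F)(F)F)n1`, differs from compound 2 by 2-(trifluoromethyl)pyrimidin-4-yl in place of 1H-benzimidazol-2-yl on an oxygen on a saturated carbon. Among the measured compounds shown here, no measured step bears on this change in a readable way; the one step available is unreadable, so it gives neither size nor direction. With both measured compounds at the limit, there is no number from which a shift could be counted.

Compound 3 is therefore expected to remain at the limit of this assay as well, with an estimate of 300000 nM and a range from 100000 nM to 1000000 nM. The step that the limit leaves unreadable from compound 2 to compound 3 is expected to be nothing beyond the scatter, and most likely only a limit will again be reported.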

Compound 3, half-maximal inhibitory concentration: 37000 nM
Estimate against measurement, compound 3: 8.1-fold (0.91 log units) above; the measured number lies below the stated range.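

The place on an oxygen on a saturated carbon can move this read-out: in this assay, with 2-(trifluoromethyl)pyrimidin-4-yl in place of 1H-benzimidazol-2-yl, the change is an at least 5.4-fold lower number from compound 2 to compound 3 (0.73 log units; beyond the scatter). Replacing the whole (4-phenyl-1,3-thiazol-2-yl)sulfanyl group with (2-(trifluoromethyl)pyrimidin-4-yl)oxy gives an at least 5.4-fold lower number from compound 1 to compound 3 (0.73 log units; beyond the scatter), so both readable steps point the same way, and each gives only a minimum size, as each starts from a limit. The shared core therefore does not hold every compound at the limit, though compound 3 is the only one here with a number: the limit of > 200000 nM in this assay, at which 2 of the 3 values shown sit.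

The ring and the trifluoromethyl enter together, so the step cannot be assigned to either one, and a methyl or a chlorine in place of the trifluoromethyl on the same pyrimidine ring would separate the two. The step from compound 1 also changes the linking sulfur to oxygen along with the ring, and a 2-(trifluoromethyl)pyrimidin-4-yl group joined through sulfur would show whether that link contributes to the step.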